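Bromo to tert-butyl on the phenyl at the aromatic nitrogen

The source may report more compounds than this note shows. Statements on the series, on what has been measured and on what is new or still open speak of the compounds shown alone.

Compound 1 `C/C(=C\CC/C(C)=C/CC[C@@H]1[C@@]2(C)CCC(=O)C(C)(C)[C@H]2CC[C@@]1(C)O)CC/C=C(\C)C(=O)OCc1cn(-c2ccccc2Br)nn1` carries 2-bromophenyl on an aromatic nitrogen of the shared core. In a functional assay on DU-145 cells (Homo sapiens) for antiproliferative activity, read by MTT assay, with a stated time of 48 h (on this read-out lower numbers stand for stronger inhibition and higher numbers for weaker inhibition), compound 1 gives only a limit, > 150000 nM. Compound 2 `C/C(=C\CC/C(C)=C/CC[C@@H]1[C@@]2(C)CCC(=O)C(C)(C)[C@H]2CC[C@@]1(C)O)CC/C=C(\C)C(=O)OCc1cn(-c2ccc(Br)cc2)nn1` carries 4-bromophenyl in place of 2-bromophenyl on that nitrogen. In this assay compound 2 likewise gives only a limit, > 150000 nM. The step that the two limits leave unreadable from compound 1 to compound 2 therefore cannot be sized, as the limit of > 150000 nM in this assay, at which 2 of the 2 values shown sit, shows. Compound 3 `C/C(=C\CC/C(C)=C/CC[C@@H]1[C@@]2(C)CCC(=O)C(C)(C)[C@H]2CC[C@@]1(C)O)CC/C=C(\C)C(=O)OCc1cn(-c2ccc(C(C)(C)C)cc2)nn1` is the next member; its difference from compound 2 is tert-butyl in place of bromo on an aromatic carbon, the bromo leaving and a tert-butyl entering on an aromatic carbon of a six-membered aromatic ring of carbon only, para to a large group. No measured step bears on this change, and the only step shown is itself unreadable, so no step beyond the scatter can be expected in this assay in either direction. Compound 3 is estimated at 200000 nM, with a range from 100000 nM to 400000 nM, and is expected to be reported again as a limit. The expected step is a step that the limit leaves unreadable from compound 2 to compound 3, within the scatter.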

Compound 3, half-maximal inhibitory concentration: > 150000 nM
Compound 3: a limit, no number; the forecaster's own chance of this, stated with the estimate: 80%; the middle value lies beyond the limit too.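

No step among compound 1, compound 2 and compound 3 can be read, because all three sit at the same limit: the limit of > 150000 nM in this assay, at which 3 of the 3 values shown sit.

Open, from the compounds shown here alone, is whether any change to these compounds gives a measurable value in this assay on the shared core.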